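Losing the (morpholin-4-yl)carbonyl of compound 3

A few compounds are considered here, and "the series" means these few. Any claim that something is new, unique, unknown or untested is made for them only; others in the source may bear on it.

Of the compounds shown here, three with a shared core have been measured in an in vivo functional assay on the whole organism for inhibition, with Rattus norvegicus as the target; on this read-out higher numbers stand for an effect only at larger amounts of compound and lower numbers for an effect already at smaller amounts. Compound 1 `CCCCc1nc(C)c(CC(=O)O)c(=O)n1Cc1ccc(-c2ccccc2-c2nnn[nH]2)cc1` gives 0.13 mg/kg, compound 2 `CCCCc1nc(C)c(CC(=O)N(CC)CC)c(=O)n1Cc1ccc(-c2ccccc2-c2nnn[nH]2)cc1` gives 0.089 mg/kg, and compound 3 `CCCCc1nc(C)c(CC(=O)N2CCOCC2)c(=O)n1Cc1ccc(-c2ccccc2-c2nnn[nH]2)cc1` gives 0.018 mg/kg. Compound 3 therefore has the lowest number of the three, and its gaps to the other two lie beyond the scatter.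

Compound 4 `CCCCc1nc(C)c(CC(=S)N(CC)CC)c(=O)n1Cc1ccc(-c2ccccc2-c2nnn[nH]2)cc1` has not yet been measured. It differs from compound 3 by a group of 7 heavy atoms (5 carbon, 1 nitrogen, 1 sulfur; no ring) in place of a group of 8 heavy atoms (5 carbon, 1 nitrogen, 2 oxygen; one six-membered non-aromatic ring with 2 hetero atoms), on a saturated chain carbon bound to an aromatic carbon. The change sits on a saturated chain carbon bound to an aromatic carbon: the ring leaves and sulfur enters.

For the measured compounds named here, three measured steps bear on this change. Diethylamino in place of hydroxy on a carbonyl carbon gave a 1.5-fold lower number from compound 1 to compound 2 (0.16 log units; within the scatter), and morpholin-4-yl in place of hydroxy gave a 7.2-fold lower number from compound 1 to compound 3 (0.86 log units; beyond the scatter). Most directly, morpholin-4-yl in place of diethylamino gave a 4.9-fold lower number from compound 2 to compound 3 (0.69 log units; beyond the scatter). Read in reverse, this last step suggests a higher number of similar size once the morpholin-4-yl ring is gone. Going by the values given here, no measured compound contains sulfur, so that part of the change remains untested and the range must stay wide.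

The expected step is a 4.4-fold higher number from compound 3 to compound 4 (0.65 log units; beyond the scatter), which is an estimate towards a higher number. For compound 4 the estimated value is 0.08 mg/kg, with an expected range of 0.025 mg/kg to 0.25 mg/kg.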

Compound 4, dose for half-maximal effect: 0.023 mg/kg
Beside the measured number, compound 4's estimate is 3.5-fold (0.54 log units) above it; the measured number lies below the stated range.
By their numbers in this assay, from the lowest: compounds 3 and 4 (each within the scatter of the next); then compounds 2 and 1 (each within the scatter of the next).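

In this assay, for the compounds shown here, the earlier compounds had left the lowest number at this saturated chain carbon with the morpholin-4-yl ring, but the result shows that the ring is not needed for a number in that range, since replacing the whole (morpholin-4-yl)carbonyl with the ringless sulfur-bearing group gives a 1.3-fold higher number from compound 3 to compound 4 (0.11 log units; within the scatter) and so stays within the scatter. It also gives the first measured effect of a change at the carbonyl oxygen itself: with the diethylamino part kept, sulfur in its place gives a 3.9-fold lower number from compound 2 to compound 4 (0.59 log units; beyond the scatter) and thus does what the morpholin-4-yl ring did, while the comparison with the free acid gives a 5.7-fold lower number from compound 1 to compound 4 (0.75 log units; beyond the scatter) on the same side. Nothing measured here explains why sulfur in this place has that effect.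

From the compounds shown here alone, it remains open whether sulfur in place of the carbonyl oxygen would change the number on the morpholin-4-yl compound as well, or on a piperidin-1-yl or dimethylamino compound. The compounds shown also leave open what a longer chain between the shared core and the sulfur-bearing carbon would do.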